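Homologation at the acetyl of the dimeric phloroglucinol series

The source may report more compounds than this note shows. Statements on the series, on what has been measured and on what is new or still open speak of the compounds shown alone.

Measured so far:
compound 1 `CC(=O)C1=C(O)C(C)(C)C(O)=C(CC2=C(O)C(C)(C)C(O)=C(C(C)=O)C2=O)C1=O` — > 50 ug/mL
compound 2 `CCC(=O)C1=C(O)C(C)(C)C(O)=C(Cc2c(O)c3c(c(C(C)=O)c2O)OC(C)(C)C=C3)C1=O` — 3.1 ug/mL

In a functional assay on KB cells (Homo sapiens) for cytotoxicity, with a stated time of 72 h (a higher number here means that more compound is needed for the effect, a lower number that less compound is needed), compound 1 gives only a limit, > 50 ug/mL, and no number. In this assay, among the compounds with values here, compound 2 gives 3.1 ug/mL, the only actual number in hand. Within the data shown here, the entry for compound 1 is a limit, so no step between the two measured compounds can be counted, and the limit of > 50 ug/mL in this assay, at which 1 of the 2 values shown sits, marks where that limit sits. Compound 2 is therefore the sole reference point for the series.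

Compound 3 `CCC(=O)C1=C(O)C(C)(C)C(O)=C(Cc2c(O)c3c(c(C(=O)CC)c2O)OC(C)(C)C=C3)C1=O` is not yet measured. It differs from compound 2 by methyl in place of hydrogen on a saturated chain carbon bound to a carbonyl carbon. Among the measured compounds shown here, no measured step of this kind exists here, so the expectation rests on the size of the change alone: an additional chain carbon on the ketone. The step from compound 2 to compound 3 is expected to be a 1.0-fold lower number from compound 2 to compound 3 (0.01 log units; within the scatter), that is none beyond the scatter. Compound 3 is thus estimated at 3 ug/mL, with a range from 1.2 ug/mL to 8 ug/mL in this assay.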

Compound 3, concentration for half-maximal effect: 4.5 ug/mL
Compound 3: the middle estimate sits 1.5-fold (0.18 log units) below what was measured; the measured number falls inside the stated range.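

Within the data shown here, the acetyl to propanoyl change, methyl in place of hydrogen on a saturated chain carbon bound to a carbonyl carbon, gives the first step that can be read, and in this assay it shows a 1.5-fold higher number from compound 2 to compound 3 (0.16 log units; within the scatter). This position therefore accepts one further chain carbon without a change beyond the scatter, so compound 3 and compound 2 stand level as far as this assay can tell. Steps involving compound 1 cannot be read, as its entry is a limit: the limit of > 50 ug/mL in this assay, at which 1 of the 3 values shown sits.

Still open, from the compounds shown here alone, is whether a longer chain such as butanoyl, or an amine or a carboxylic acid at the end of this chain, would stay level with compound 2. Also open, going by these compounds, is whether this level reading extends beyond this assay to other cell types.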